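Cytotoxicity notes on an isopropyl-pyrazolopyridine amide series

The source may hold more compounds than are shown below. What is called first, only, known or untested is meant among the compounds shown, and "the series" means these compounds.

Measured so far:
compound 1 `CC(C)n1ncc2c(C(=O)Nc3c(F)cc(F)cc3F)cc(-c3cccs3)nc21` — > 200000 nM
compound 2 `CC(C)n1ncc2c(C(=O)Nc3ccc(F)cc3)cc(-c3ccco3)nc21` — > 200000 nM

Both measured compounds share the core of compound 1 and were run in an ADME assay on LLC-MK2 cells (Macaca mulatta) for cytotoxicity, read by spectrophotometry and crystal violet staining, with a stated time of 4 days; on this read-out higher numbers stand for lower toxicity in this test and lower numbers for higher toxicity in this test. For compound 1 the result is a limit of the assay and not a number, > 200000 nM. For compound 2 the result is likewise a limit, > 200000 nM. For the measured compounds named here, compound 1 therefore stands at the limit of > 200000 nM in this assay, at which 2 of the 2 values shown sit; no measured step between the two compounds can be given, and the two values show only that neither reaches a measurable toxicity in this test.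

The next compound, compound 3 `CC(C)n1ncc2c(C(=O)Nc3ccncc3)cc(-c3cccs3)nc21`, differs from compound 1 in one place: pyridin-4-yl in place of 2,4,6-trifluorophenyl on an amide-type nitrogen. The amide-type nitrogen and its carbonyl neighbour are kept.

Going by the values given here, with no measured step available, the expectation for the change from compound 1 to compound 3 in this assay is no step beyond the usual scatter, since both values shown sit at the limit. The step of a number no higher from compound 1 to compound 3 (the limit leaves the size open) is the estimate implied. For compound 3 the expected value is 200000 nM, with a range from 60000 nM to 400000 nM, and most likely the assay again reports only a limit.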

Compound 3, half-maximal cytotoxic concentration: 6300 nM
The estimate for compound 3 lay 32-fold (1.50 log units) above the measured number; measured number outside the range, below it.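

In this assay, pyridin-4-yl in place of 2,4,6-trifluorophenyl on the amide-type nitrogen gives an at least 31-fold lower number from compound 1 to compound 3 (1.50 log units; beyond the scatter), so a change at this one place, with the carbonyl neighbour and the rest of compound 1 kept, is enough to bring toxicity in this test into the measurable range. Compound 1 gives > 200000 nM, which is a limit of the assay and not a number. Compound 3 is the only compound shown with a number rather than a limit, so this position is now known to matter, while the full size of the step stays open: the limit of > 200000 nM in this assay, at which 2 of the 3 values shown sit.

The change replaces the ring and removes the fluorine atoms in one move, and the compounds shown do not separate the ring nitrogen from the loss of fluorine. A plain phenyl group on the same amide-type nitrogen would divide these two parts of the change, and a pyridin-4-yl group carrying an amine would show whether the number for compound 3 holds up when that ring is further substituted.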